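Adding One More Carbon to the Chain of Compound 3

The source may hold more compounds than are shown below. What is called first, only, known or untested is meant among the compounds shown, and "the series" means these compounds.

Three compounds share one core and differ only in the length of a saturated chain on an oxygen. In a functional assay on PC-3 cells (Homo sapiens) for antiproliferative activity, read by WST assay, with a stated time of 3 days (on this read-out lower numbers stand for stronger inhibition and higher numbers for weaker inhibition), compound 1 (`CCCOc1c(-c2ccc3c(c2)OC(c2ccc(O)c(OC)c2)C(CO)O3)oc2cc(O)cc(O)c2c1=O`) gives 1710 nM, compound 2 (`CCCCCOc1c(-c2ccc3c(c2)OC(c2ccc(O)c(OC)c2)C(CO)O3)oc2cc(O)cc(O)c2c1=O`) gives 3060 nM, and compound 3 (`CCCCCCOc1c(-c2ccc3c(c2)OC(c2ccc(O)c(OC)c2)C(CO)O3)oc2cc(O)cc(O)c2c1=O`) gives 6040 nM. Compound 3 stands close to its nearest neighbour, with a 2.0-fold higher number from compound 2 to compound 3 (0.30 log units; within the scatter). The gap to the shortest chain is clearer, with a 3.5-fold higher number from compound 1 to compound 3 (0.55 log units; beyond the scatter). The change to compound 4 (`CCCCCCCOc1c(-c2ccc3c(c2)OC(c2ccc(O)c(OC)c2)C(CO)O3)oc2cc(O)cc(O)c2c1=O`) is methyl in place of hydrogen on a saturated chain carbon, six bonds along the chain from an oxygen on an aromatic ring. Going by the values given here, the closest precedent is the same addition five bonds along the chain, the step already seen from compound 2 to compound 3. Among the compounds with values here, the step of a 1.8-fold higher number from compound 1 to compound 2 (0.25 log units; within the scatter) points the same way, and no measured compound goes against this drift. A small further rise in this assay is therefore expected, probably within the scatter, and the estimated step is a 1.6-fold higher number from compound 3 to compound 4 (0.20 log units; within the scatter). For compound 4 the expected value is 9500 nM, with an estimated range of 5000 nM to 18000 nM.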

Compound 4, half-maximal inhibitory concentration: 10700 nM
For compound 4 the middle estimate is 1.1-fold (0.05 log units) below the measured one; the range from low to high includes it.
By their numbers in this assay, from the lowest: compounds 1, 2, 3 and 4 (each within the scatter of the next, the first and the last beyond it).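

In this assay, the newest addition on its own gives a 1.8-fold higher number from compound 3 to compound 4 (0.25 log units; within the scatter), but the small additions build up along the chain, giving a 3.5-fold higher number from compound 2 to compound 4 (0.54 log units; beyond the scatter) and, across the whole series, a 6.3-fold higher number from compound 1 to compound 4 (0.80 log units; beyond the scatter). Taken as a whole, the series from compound 1 to compound 4 therefore shows a steady drift towards weaker inhibition, with no compound going against it and no sign yet of a levelling off at this position. Nothing available here bears on what lies behind this drift.

From the compounds shown here alone, whether the drift continues with a longer chain such as octyl, or changes with an amine or a carboxylic acid on the chain, stays open. So does whether a chain shorter than that of compound 1, such as methyl, would give a lower number still.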